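Fluorophenyl carbamates against fatty-acid amide hydrolase

This account rests on a few compounds, and the source may have more. Where it says the series, first, only, none or still open, it means among the compounds named here.

Two carbamates share one core and differ only in the aryl group on the oxygen next to the carbonyl group. Compound 1 `CCCCOc1ccc(CNC(=O)Oc2cccc(Cl)c2)cc1` carries a 3-chlorophenyl there, and in an assay on H4 cells for inhibition of Fatty-acid amide hydrolase 1 (Homo sapiens) (a lower number here means a stronger inhibitor, a higher number a weaker inhibitor), compound 1 gives 12 nM. Compound 2 `CCCCOc1ccc(CNC(=O)Oc2ccccc2F)cc1` carries a 2-fluorophenyl, and in this assay compound 2 gives 9.2 nM. Compound 2 holds the lowest of the two numbers, yet the step of a 1.3-fold lower number from compound 1 to compound 2 (0.12 log units; within the scatter) stays within the scatter, so the two cannot be told apart. Compound 3 `CCCCOc1ccc(CNC(=O)Oc2ccc(F)cc2)cc1` has not been measured; it differs from compound 2 by 4-fluorophenyl in place of 2-fluorophenyl on an oxygen next to a carbonyl group. For the measured compounds named here, no measured pair covers this exact change; the only step available, a 1.3-fold lower number from compound 1 to compound 2 (0.12 log units; within the scatter), shows that swapping the aryl group moved the number by less than the scatter. The expected step is therefore a 1.1-fold higher number from compound 2 to compound 3 (0.04 log units; within the scatter), with nothing beyond the scatter expected. Compound 3 is estimated at 10 nM, within 4 nM to 25 nM.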

Compound 3, half-maximal inhibitory concentration: 4.6 nM
For compound 3 the middle estimate is 2.2-fold (0.34 log units) above the measured one; the measured number falls inside the stated range.
By their numbers in this assay, from the lowest: compounds 3, 2 and 1 (each within the scatter of the next, the first and the last beyond it).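

With a 2.0-fold lower number from compound 2 to compound 3 (0.30 log units; within the scatter), the 4-fluorophenyl and the 2-fluorophenyl still cannot be told apart in this assay. The step of a 2.6-fold lower number from compound 1 to compound 3 (0.42 log units; beyond the scatter), however, is the first among these compounds to pass beyond the scatter, showing that the aryl group on the oxygen next to a carbonyl group can shift the number, if only modestly. Nothing available here bears on why it does.

Compound 1 and compound 3 differ in both the halogen and the name of the aryl group, so a 4-chlorophenyl or a 3-fluorophenyl would be needed to separate those two changes. As far as these compounds go, how a 4-aminophenyl or a 4-methoxyphenyl would read at this place stays open, as does the effect of a longer chain on the shared core.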